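A few compounds are considered here, and "the series" means these few. Any claim that something is new, unique, unknown or untested is made for them only; others in the source may bear on it.

Compound 3 `COC(=O)C1=C(C)N=C(C)/C(=C(\O)OC)C1c1cccc(Cl)c1Cl` gives the lowest number of the three compounds tested in a functional assay (muscle tissue) with Cavia porcellus as the target (a lower number here means that less compound is needed, a higher number that more compound is needed for the effect), with a half-maximal effective concentration of 19.1 nM. Compound 2 `COC(=O)C1=C(C)N=C(C)/C(=C(\O)OC)C1c1cccc(C)c1` comes nearest, at 110 nM, and compound 1 `COC(=O)C1=C(C)N=C(C)/C(=C(\O)OC)C1c1cccc(N)c1` is furthest, at 2000 nM. The steps already seen are an 18-fold lower number from compound 1 to compound 2 (1.26 log units; beyond the scatter), a 100-fold lower number from compound 1 to compound 3 (2.02 log units; beyond the scatter) and a 5.8-fold lower number from compound 2 to compound 3 (0.76 log units; beyond the scatter).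

Compound 4 `COC(=O)C1=C(C)N=C(C)/C(=C(\O)OC)C1c1ccc(Cl)cc1Cl` has not been measured. It differs from compound 3 in one place: 2,4-dichlorophenyl in place of 2,3-dichlorophenyl on a saturated ring carbon. The two compounds carry the same atoms joined differently. Going by the values given here, none of the measured steps compares two dichlorophenyl groups with each other; the steps from compound 1 and compound 2 to compound 3 show only that a dichlorophenyl group brought the lowest number seen so far. Among the compounds with values here, no measured step therefore bears directly on this change, and the step of a 1.3-fold higher number from compound 3 to compound 4 (0.12 log units; within the scatter) is expected to lie within the scatter or only slightly beyond it. Compound 4 is estimated to give 25 nM in this assay, within a range from 8 nM to 80 nM.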

Compound 4, half-maximal effective concentration: 640 nM
Compound 4: the middle estimate sits 26-fold (1.41 log units) below what was measured; the whole stated range lies below it.
By their numbers in this assay, from the lowest: compound 3; then compound 2; then compound 4; then compound 1.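

In this assay, the arrangement of the two chlorines proves to matter on its own: with the same atoms joined differently, the change is large (a 34-fold higher number from compound 3 to compound 4 (1.53 log units; beyond the scatter)), so the low number of compound 3 belongs to the 2,3-dichlorophenyl group and not to dichlorophenyl groups in general. The 2,4-dichlorophenyl group also gives up the advantage over the 3-methylphenyl group (a 5.8-fold higher number from compound 2 to compound 4 (0.76 log units; beyond the scatter)) and keeps only a modest edge over the 3-aminophenyl group (a 3.1-fold lower number from compound 1 to compound 4 (0.49 log units; beyond the scatter)). No evidence is available that accounts for this difference between the two dichlorophenyl groups.

The compounds shown leave open how a phenyl group carrying a single chlorine, a nitro group or a methoxy group would compare on this saturated ring carbon. They also leave open whether the gap between the two dichlorophenyl groups would persist with an ethoxycarbonyl group in place of the methoxycarbonyl group.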